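Z to E on the weakest of three compounds

A few compounds are considered here, and "the series" means these few. Any claim that something is new, unique, unknown or untested is made for them only; others in the source may bear on it.

Measured in a functional assay on HT-29 cells (Homo sapiens) for cytotoxicity; on this read-out higher numbers stand for weaker inhibition and lower numbers for stronger inhibition:
- compound 1 `COc1cc(/C=C\c2ccc3ccccc3n2)cc(OC)c1OC`: 316 nM
- compound 2 `COc1cc(/C=C\c2ccc3cccnc3c2)cc(OC)c1OC`: 158 nM
- compound 3 `COc1cc(/C=C\c2ccc3nccnc3c2)cc(OC)c1OC`: 7940 nM

The values of compound 1 and compound 2 lie within the scatter of each other. Compound 3 stands apart at 7940 nM, the highest number of the three and beyond the scatter of both others, which makes it the weakest inhibitor so far in this assay.

The next compound to be measured is compound 4 `COc1cc(/C=C/c2ccc3nccnc3c2)cc(OC)c1OC`. Against compound 3 the change is the two compounds have the same atoms and bonds and differ only in configuration as drawn: 1 of 1 stereo elements differ; a double bond is drawn Z in compound 3 and E in compound 4. Among the measured compounds shown here, all three measured compounds have the double bond drawn Z, so no measured pair shows what this change does, and any expectation here is weakly grounded. The expectation is a higher number, meaning weaker inhibition, with a moderate step that probably lies beyond the scatter, although no change at all cannot be excluded. The expected step is a 2.5-fold higher number from compound 3 to compound 4 (0.40 log units; beyond the scatter). For compound 4 the estimated value is 20000 nM. The expected range for compound 4 runs from 6000 nM to 60000 nM.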

Compound 4, half-maximal inhibitory concentration: > 15800 nM
Compound 4: no number, only a limit (the forecaster's own chance of this, stated with the estimate: 30%); the middle value lies beyond the limit too.
By their numbers in this assay, from the lowest: compounds 2 and 1 (each within the scatter of the next); then compound 3. At a limit, above all of these: compound 4.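

In this assay compound 4 gives only a limit, > 15800 nM, and not a number. The comparison with compound 3 yields an at least 1.9-fold higher number from compound 3 to compound 4 (0.29 log units; that floor lies within the scatter), so the E form shows no measurable gain over the Z form, but the printed floor alone does not establish a loss beyond the scatter. The earlier compounds all carried the double bond drawn Z, so this is the first comparison in the series that isolates the configuration at this position, and it is a clean one, resting on: the fact that compounds 3 and 4 differ only in the configuration as drawn

Still open is the true size of this step, and whether the E form behaves in the same way on the cores of compound 1 and compound 2, which are shown only as Z and have much lower numbers than compound 3. Also open is how the series responds when the double bond itself is replaced, for example by an amide or a carbonyl, since every compound shown keeps the double bond and differs only in its configuration or in the ring system attached to it.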